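The source may hold more compounds than are shown below. What is called first, only, known or untested is meant among the compounds shown, and "the series" means these compounds.

Compound 2 `O=S(=O)(CCC(F)=C(F)F)c1nccs1` is the starting point here. In a functional assay on HepG2 cells (Homo sapiens) for cytotoxicity, read by MTT assay, with a stated time of 48 h (on this read-out higher numbers stand for weaker inhibition and lower numbers for stronger inhibition), compound 2 reaches only the limit of the assay, > 120000 nM, so no number is known for it. Compound 3 `O=S(=O)(CCC(F)=C(F)F)c1nc2ccccc2[nH]1` likewise gives only the limit > 120000 nM. Compound 1 `[O-][S+](CCC(F)(Cl)C(F)(F)Cl)c1nc2ccccc2s1`, built on a different core, gives 13500 nM. The picture is shaped by the limit of > 120000 nM in this assay, at which 2 of the 3 values shown sit. Compound 4 `O=S(=O)(CCC(F)=C(F)F)c1ncc(-c2ccncc2)s1` differs from compound 2 by pyridin-4-yl in place of hydrogen on an aromatic carbon. No measured step of this kind exists among these compounds. Because compound 2 stands only at the limit > 120000 nM, any expected step is loosely anchored. A modest gain in cytotoxicity, at or just beyond the scatter, is expected, amounting to an at least 2.0-fold lower number from compound 2 to compound 4 (0.30 log units; that floor lies within the scatter). Compound 4 is expected to give 60000 nM, most likely between 15000 nM and 200000 nM.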

Compound 4, half-maximal inhibitory concentration: > 120000 nM
Compound 4: a limit, no number; the forecaster's own chance of this, stated with the estimate: 45%; middle value at least 2.0-fold (0.30 log units) from the limit.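

Among the compounds shown here, compound 4, like compound 2, stands only at a limit, so no step between these two compounds can be read: the limit of > 120000 nM in this assay, at which 3 of the 4 values shown sit. Going by these compounds, whether pyridin-4-yl in place of hydrogen changes cytotoxicity at all stays open.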